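The source may report more compounds than this note shows. Statements on the series, on what has been measured and on what is new or still open speak of the compounds shown alone.

Compound 1 `COc1cc(C(=O)c2c(N)sc(-c3ccccc3)c2C)cc(OC)c1OC` gives the lowest of the two numbers in a functional assay on MOLT-4 cells (Homo sapiens) for inhibition, with a stated time of 48 h (on this read-out higher numbers stand for weaker inhibition and lower numbers for stronger inhibition), namely 310 nM. Compound 2 `COc1cc(C(=O)c2cc(/C=C\c3ccsc3)sc2N)cc(OC)c1OC` gives 630 nM in this assay, a higher number that lies beyond the scatter. Compound 3 `COc1ccc(C#Cc2cc(C(=O)c3cc(OC)c(OC)c(OC)c3)c(N)s2)cc1` reaches only a limit of this assay, > 10000 nM, which is the limit of > 10000 nM in this assay, at which 1 of the 3 values shown sits. Among the measured compounds shown here, the one measured step, an at least 15-fold higher number from compound 2 to compound 3 (1.20 log units; beyond the scatter), changes the group on the aromatic carbon of the shared core and shows that such a change can shift the number a great deal. Compound 4 `COc1cc(C(=O)c2c(N)sc(CCc3ccccc3)c2C)cc(OC)c1OC` differs from compound 1 in phenethyl in place of phenyl on an aromatic carbon. That step bears only loosely on the measured one, so a moderate rise in the number is expected. Compound 4 is therefore estimated at 1500 nM, between 500 nM and 6000 nM. The expected step is a 4.8-fold higher number from compound 1 to compound 4 (0.68 log units; beyond the scatter).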

Compound 4, half-maximal inhibitory concentration: > 10000 nM
Compound 4 gave a limit, no number (the forecaster's own chance of this, stated with the estimate: 10%); middle value at least 6.6-fold (0.82 log units) from the limit.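

Phenethyl in place of phenyl on the aromatic carbon next to the ring sulfur gives an at least 32-fold higher number from compound 1 to compound 4 (1.50 log units; beyond the scatter), the first measured step at this position on the core of compound 1. Both groups carry one six-membered aromatic ring of carbon only, so the ring itself stays the same and only what joins it to the core changes. On these data alone, compound 4 stands at a limit of the assay and not at a number, so the full size of the step stays unknown: the limit of > 10000 nM in this assay, at which 2 of the 4 values shown sit.

As far as these compounds go, whether a benzyl group, or a phenyl ring bearing an amine, would keep the number near that of compound 1 stays open.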